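Hydrazone aryl swap on a shared triazine sulfonamide core

A few compounds are considered here, and "the series" means these few. Any claim that something is new, unique, unknown or untested is made for them only; others in the source may bear on it.

Compound 1 `NS(=O)(=O)c1ccc(Nc2nc(N/N=C/c3ccc(C(F)(F)F)cc3)nc(Nc3ccccc3)n2)cc1`: 37500 nM
Compound 2 `Cc1nn(-c2ccccc2)cc1/C=N/Nc1nc(Nc2ccccc2)nc(Nc2ccc(S(N)(=O)=O)cc2)n1`: > 100000 nM

In a functional assay on SNB-75 cells (Homo sapiens) for inhibition, read by sulforhodamine B assay, with a stated time of 48 h (a lower number here means that less compound is tolerated, a higher number that more compound is tolerated), compound 1 gives 37500 nM. Compound 2 gives > 100000 nM, which is a limit of the assay and not a number. Going by the values given here, the one measured step, an at least 2.6-fold higher number from compound 1 to compound 2 (0.42 log units; beyond the scatter), rests on (the limit of > 100000 nM in this assay, at which 1 of the 2 values shown sits), so its true size is unknown. Compound 3 `NS(=O)(=O)c1ccc(Nc2nc(N/N=C/c3ccccn3)nc(Nc3ccccc3)n2)cc1` carries pyridin-2-yl in place of 3-methyl-1-phenyl-1H-pyrazol-4-yl on a carbon with a double bond to nitrogen. Among the compounds with values here, no measured step covers this change; compound 3 merely returns to a single six-membered ring, as compound 1 has. Compound 3 is therefore expected near 60000 nM (range 20000 nM to 150000 nM), a step estimated at an at least 1.6-fold lower number from compound 2 to compound 3 (0.22 log units; that floor lies within the scatter).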

Compound 3, concentration lethal to 50% of the cells: 5710 nM
Compound 3: the middle estimate sits 11-fold (1.02 log units) above what was measured, outside the stated range (below it).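

A single six-membered aromatic ring on the carbon with a double bond to nitrogen does not by itself set the number in this assay: pyridin-2-yl in place of 4-(trifluoromethyl)phenyl gives a 6.6-fold lower number from compound 1 to compound 3 (0.82 log units; beyond the scatter). Compound 3 therefore has the lowest number of the three, and replacing 3-methyl-1-phenyl-1H-pyrazol-4-yl with pyridin-2-yl gives an at least 17-fold lower number from compound 2 to compound 3 (1.24 log units; beyond the scatter). That step is only a floor, and its true size is unknown: the limit of > 100000 nM in this assay, at which 1 of the 3 values shown sits.

The compounds shown leave open whether the ring nitrogen of pyridin-2-yl matters or simply the absence of trifluoromethyl. A plain phenyl or a pyridin-3-yl at this place would separate the two.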